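Methoxy to ethoxy on compound 2: cytotoxicity outlook

The source may report more compounds than this note shows. Statements on the series, on what has been measured and on what is new or still open speak of the compounds shown alone.

Three members of the series have been run through an ADME assay on Vero cells (Chlorocebus sabaeus) for cytotoxicity, read by MTT assay, with a stated time of 72 h; on this read-out lower numbers stand for higher toxicity in this test and higher numbers for lower toxicity in this test. Compound 1 `COc1c(N2C[C@H]3CCCN(Cc4cn(CCCN5C(=O)C(=O)c6cc(F)ccc65)nn4)[C@H]3C2)c(F)cc2c(=O)c(C(=O)O)cn(C3CC3)c12` gives 16 ug/mL. Compound 3 `COc1c(N2C[C@H]3CCCN(Cc4cn(CCCN5C(=O)/C(=N/O)c6cc(C)ccc65)nn4)[C@H]3C2)c(F)cc2c(=O)c(C(=O)O)cn(C3CC3)c12` gives 8 ug/mL. Compound 2 `CO/N=C1/C(=O)N(CCCn2cc(CN3CCC[C@@H]4CN(c5c(F)cc6c(=O)c(C(=O)O)cn(C7CC7)c6c5OC)C[C@@H]43)nn2)c2ccc(F)cc21` gives 4 ug/mL, the lowest of the three numbers; its gap to compound 3 is within the scatter, while its gap to compound 1 lies beyond it. Among the measured compounds shown here, no two of these measured compounds differ in one place only, so no single-point step within the measured set can be read off.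

Compound 4 `CCO/N=C1/C(=O)N(CCCn2cc(CN3CCC[C@@H]4CN(c5c(F)cc6c(=O)c(C(=O)O)cn(C7CC7)c6c5OC)C[C@@H]43)nn2)c2ccc(F)cc21` differs from compound 2 by methyl in place of hydrogen on a saturated chain carbon bound to an oxygen on an unsaturated carbon, cut one bond further out a change of methoxy to ethoxy. The change adds one carbon and nothing else, and nothing in the measured set speaks to a change of this kind. The expected step in this assay is a 1.3-fold higher number from compound 2 to compound 4 (0.10 log units; within the scatter), none beyond the scatter. For compound 4 in this assay the estimate is 5 ug/mL, with a range from 2 ug/mL to 12 ug/mL.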

Compound 4, half-maximal cytotoxic concentration: 4 ug/mL
Beside the measured number, compound 4's estimate is 1.3-fold (0.10 log units) above it; the range from low to high includes it.
By their numbers in this assay, from the lowest: compounds 2, 4, 3 and 1 (each within the scatter of the next, the first and the last beyond it).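

Methyl in place of hydrogen on a saturated chain carbon bound to an oxygen on an unsaturated carbon gives the series its only step at a single place, and in this assay it reads as no change at the digits printed from compound 2 to compound 4 (within the scatter). The earlier compounds shown here held no pair differing in one place, so nothing could be read about this position until now. Here, methoxy to ethoxy leaves the read-out undisturbed within the limits of this one pair, and that finding applies only to this change on this core.

On these data alone, whether a longer chain such as butoxy, or a chain ending in an amine or a carboxylic acid, would leave this assay as undisturbed remains open. No measurement shown here accounts for the absence of a step at this position.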